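Swapping Carboxy for Benzyloxy: an Expected Cytotoxicity Value

A few compounds are considered here, and "the series" means these few. Any claim that something is new, unique, unknown or untested is made for them only; others in the source may bear on it.

Three compounds with a shared core were tested in an ADME assay on L929 cells (Mus musculus) for cytotoxicity, read by resazurin assay, with a stated time of 72 h; a higher number here means a weaker inhibitor, a lower number a stronger inhibitor. Compound 1 `O=C(/C=C/c1ccc2c(c1)B(O)OC2)c1ccc(Cl)c(Cl)c1` gives > 10 ug/mL, which is a limit of the assay rather than a number. Compound 2 `O=C(O)c1ccc(C(=O)/C=C/c2ccc3c(c2)B(O)OC3)cc1` gives > 10 ug/mL, again a limit and not a number. Compound 3 `COc1ccccc1C(=O)/C=C/c1ccc2c(c1)B(O)OC2` gives a measured value of 6.35 ug/mL. Compound 2 therefore sits at the limit of > 10 ug/mL in this assay, at which 2 of the 3 values shown sit, with no number of its own.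

Compound 4 `O=C(/C=C/c1ccc2c(c1)B(O)OC2)c1ccc(OCc2ccccc2)cc1` is not yet measured; its change from compound 2 is benzyloxy in place of carboxy on an aromatic carbon. Among the measured compounds shown here, no measured pair shows this change, so no size of step is known. The step is expected to be small or none beyond the scatter, with compound 4 near the limit. The estimate for compound 4 is 8 ug/mL, between 3 ug/mL and 20 ug/mL, an expected step of an at least 1.2-fold lower number from compound 2 to compound 4 (0.09 log units; that floor lies within the scatter).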

Compound 4, half-maximal inhibitory concentration: > 10 ug/mL
Compound 4 was reported as a limit (the forecaster's own chance of this, stated with the estimate: 50%); at least 1.2-fold (0.09 log units) between middle value and limit.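

Compound 2 and compound 4 are both reported only as limits, so no step between them can be read: the limit of > 10 ug/mL in this assay, at which 3 of the 4 values shown sit.

Going by these compounds, what benzyloxy in place of carboxy does to the number in this assay stays open.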